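The source may hold more compounds than are shown below. What is called first, only, known or untested is meant among the compounds shown, and "the series" means these compounds.

Measured compounds in an assay for inhibition of kynurenine 3-monooxygenase (Homo sapiens), read by mass spectrometry, with a stated time of 1 h; a higher number here means a weaker inhibitor, a lower number a stronger inhibitor:
- compound 1, `Cc1ccc([C@@H](C)Oc2cc3onc(CCC(=O)O)c3cc2Cl)nc1`; compound 1 gives 3.16 nM
- compound 2, `CC(C)Cc1cc2oc(=O)n(CCC(=O)O)c2cc1Cl`; compound 2 gives 12.6 nM
- compound 3, `C[C@@H](Oc1cc2oc(=O)n(CCC(=O)O)c2cc1Cl)c1cccnn1`; compound 3 gives 1.26 nM

Compound 1 holds the second highest of the three numbers. Its nearest neighbour is compound 3, whose lower number lies beyond the usual scatter; the furthest is compound 2, whose higher number also lies beyond it. For the measured compounds named here, both compound 2 and compound 3 differ from compound 1 in more than one place, so no single-point step between measured compounds is available, and the values of compound 2 and compound 3 say only that the series spans a modest range on either side of compound 1.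

Compound 4, `C[C@@H](Oc1cc2onc(CCC(=O)O)c2cc1Cl)c1ccc(F)cn1`, keeps the rest of compound 1 unchanged; the difference is fluoro in place of methyl on an aromatic carbon. Nothing measured here isolates that exchange. Given the small size of the change, the step of a 1.1-fold higher number from compound 1 to compound 4 (0.04 log units; within the scatter) is expected to be none beyond the scatter, with no preferred direction. Compound 4 is accordingly estimated at 3.5 nM, with a range from 1.2 nM to 10 nM, resting on the value of compound 1 in this assay.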

Compound 4, half-maximal inhibitory concentration: 3.16 nM
Compound 4: middle estimate off by 1.1-fold (0.04 log units), on the high side; measured number inside the range.
By their numbers in this assay, from the lowest: compound 3; then compounds 1 and 4 (each within the scatter of the next); then compound 2.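

In this assay, the only single-point step among the compounds shown, 5-methylpyridin-2-yl to 5-fluoropyridin-2-yl, reads no change at the digits printed from compound 1 to compound 4 (within the scatter). This position, two atoms from the ring nitrogen and para to a large group, therefore accepts fluoro or methyl with no difference beyond the scatter, something compound 2 and compound 3 could not show, as each differs from compound 1 in more than one place. No measurement at hand bears on the origin of this result.

The finding covers only these two single-atom groups, so a larger or different group at this position, such as methoxy, trifluoromethyl, nitrile or an amine, remains untested within the compounds shown, and the limits of what the position accepts stay undefined. On these data alone, whether fluoro in place of methyl also reads the same on a core other than that of compound 1 stays open as well.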